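The compounds below may be only part of what the source reports. "The series", "measured", "known", "first", "only" and "open" are said of these compounds alone.

In a physicochemical assay for solubility, at pH 1.1 (a higher number here means a more soluble compound, a lower number a less soluble compound), compound 3 `CCCN(Cc1ccc(OCCn2c(=O)ccn(C)c2=O)c(C)c1)C(CC(=O)O)c1ccc(Cl)cc1` gives 3000000 nM, level with compound 1 `Cc1cc(CN(CC2CC2)C(CC(=O)O)c2ccc(Cl)cc2)ccc1OCCN1C(=O)CCC1=O` at 3000000 nM and compound 2 `Cc1cc(CN(C)C(CC(=O)O)c2ccc(Cl)cc2)ccc1OCCn1c(=O)ccn(C)c1=O` at 3000000 nM. Compound 4 `Cc1cc(CN(CC2CC2)C(CC(=O)O)c2ccc(Cl)cc2)ccc1OCCn1c(=O)ccn(C)c1=O` differs from compound 3 by a single change, cyclopropyl in place of ethyl on a saturated chain carbon bound to an amine nitrogen. Within the data shown here, the one measured step at that place, no change at the digits printed from compound 2 to compound 3 (within the scatter), stayed within the scatter, and it is the only step that bears on this change. No shift beyond the scatter is therefore expected in this assay, and the expected step is no change at the digits printed from compound 3 to compound 4 (within the scatter). For compound 4 the estimated value is 3000000 nM, with an expected range from 2000000 nM to 3500000 nM.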

Compound 4, solubility: 3000000 nM
Estimate against measurement, compound 4: no gap at the digits printed; the range from low to high includes it.
By their numbers in this assay, from the lowest: compounds 1, 2, 3 and 4 (each within the scatter of the next).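

Cyclopropyl brings the first ring to the place on a saturated chain carbon bound to an amine nitrogen, and in this assay this gives no change at the digits printed from compound 3 to compound 4 (within the scatter), while cyclopropyl in place of hydrogen gives no change at the digits printed from compound 2 to compound 4 (within the scatter). The group of 9 heavy atoms with its six-membered aromatic ring, in place of the five-membered non-aromatic ring group, opens a second place and gives no change at the digits printed from compound 1 to compound 4 (within the scatter). No measurement shown accounts for these results.

On these data alone, whether an amine or a longer chain at the first place would shift this assay remains open. So does the effect of replacing the carboxylic acid.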